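This account rests on a few compounds, and the source may have more. Where it says the series, first, only, none or still open, it means among the compounds named here.

Measured so far in a functional assay on A-375 cells (Homo sapiens) for cytotoxicity, read by MTT assay, with a stated time of 72 h, tested at 1 uM; on this read-out higher numbers stand for more inhibition of growth at the one concentration tested and lower numbers for less inhibition of growth:
compound 1 `N/C(=N\NC(=S)N1CCOCC1)c1ccccn1`: 26.8%
compound 2 `N/C(=N\NC(=S)N1CCCCC1)c1ccccn1`: 72.5%
compound 3 `Cc1cccc(/C(N)=N/NC(=S)N2CCCC2)n1`: 13.6%

Compound 3 stands lowest of the three; compound 1 sits above it by a margin beyond the scatter, and compound 2 lies far above both. Among the compounds with values here, the one step through a single change is a number 45.7 percentage points higher from compound 1 to compound 2 (beyond the scatter), a large gain within the unsubstituted core.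

Compound 4 `N/C(=N\NC(=S)N1CCCC1)c1ccccn1` follows from compound 3 by hydrogen in place of methyl on an aromatic carbon, on the aromatic carbon next to the ring nitrogen. Within the data shown here, no measured pair shows this change, so the step from compound 1 to compound 2 bears on it only indirectly: it indicates that the ring on the thiocarbonyl carbon moves the read-out strongly, while the methyl's own weight is unknown. Compound 4 shares its core with compounds 1 and 2, and their values span a wide interval, which widens the uncertainty. A moderate rise for compound 4 is expected, a number 26.4 percentage points higher from compound 3 to compound 4 (beyond the scatter), with a broad range. Compound 4 is estimated at 40%, between 10% and 75%.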

Compound 4, percent growth inhibition at one concentration: 65.7%
Estimate against measurement, compound 4: 25.7 percentage points below, and the stated range covers the measured number.
By their numbers in this assay, from the lowest: compound 3; then compound 1; then compounds 4 and 2 (each within the scatter of the next).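

In this assay, within the data shown here, hydrogen in place of methyl on an aromatic carbon next to the ring nitrogen gives a number 52.1 percentage points higher from compound 3 to compound 4 (beyond the scatter) with pyrrolidin-1-yl on the thiocarbonyl carbon, the first reading of this position, and the methyl goes with a large loss in this pair. Within the shared core, pyrrolidin-1-yl in place of piperidin-1-yl gives a number 6.8 percentage points lower from compound 2 to compound 4 (within the scatter) while pyrrolidin-1-yl in place of morpholin-4-yl gives a number 38.9 percentage points higher from compound 1 to compound 4 (beyond the scatter) so among these three ring groups morpholin-4-yl alone stands apart. No measurement at hand gives a reason for these steps.

Going by these compounds, whether methyl costs as much with piperidin-1-yl or morpholin-4-yl on the thiocarbonyl carbon remains open. So does the reading of ethyl, methoxy or chlorine on this aromatic carbon.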